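This account rests on a few compounds, and the source may have more. Where it says the series, first, only, none or still open, it means among the compounds named here.

Two compounds share one core and differ only in where a phenyl ring sits on the five-membered ring of that core. Compound 1 `O=C(NCCCCc1ccccc1)n1c(-c2ccccc2)coc1=O` gives 70 nM in an assay on isolated protein for inhibition of acid ceramidase (Homo sapiens), read by LC-MS, with a stated time of 1 h; on this read-out higher numbers stand for weaker inhibition and lower numbers for stronger inhibition. Compound 2 `O=C(NCCCCc1ccccc1)n1cc(-c2ccccc2)oc1=O` gives 90 nM in this assay; this is the higher of the two numbers on paper, yet its gap to compound 1 lies within the usual scatter of repeated measurements, so the two cannot be told apart on these data.

Compound 3 `O=C(NCCCCc1ccccc1)n1cc(-c2cccnc2)oc1=O` has not yet been measured. It is built from compound 2 by one change: pyridin-3-yl in place of phenyl on an aromatic carbon. For the measured compounds named here, no measured pair here shows what such a ring swap does in this assay, so any expectation rests on the size of change that such a small swap commonly brings rather than on a number seen. The expected step is a 2.0-fold higher number from compound 2 to compound 3 (0.30 log units; within the scatter), a modest move toward weaker inhibition, of a size barely beyond the scatter. On that basis compound 3 is estimated to give 180 nM in this assay, with a likely range from 60 nM to 600 nM.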

Compound 3, half-maximal inhibitory concentration: 70 nM
Compound 3: the middle estimate sits 2.6-fold (0.41 log units) above what was measured; the range from low to high includes it.
By their numbers in this assay, from the lowest: compounds 1, 3 and 2 (each within the scatter of the next).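

In this assay, putting pyridin-3-yl in place of phenyl on the aromatic carbon next to the ring oxygen gives a 1.3-fold lower number from compound 2 to compound 3 (0.11 log units; within the scatter), so the two compounds cannot be told apart. For the compounds shown here, this is the first measured swap at this position, and it shows that one carbon of the six-membered aromatic ring can be exchanged for a nitrogen, adding a hydrogen-bond acceptor to the count, with no change that this read-out can resolve. Nothing measured here explains why the number stays within the scatter.

The compounds shown leave open whether pyridin-2-yl or pyridin-4-yl on this same carbon would fare like pyridin-3-yl, and whether an amine or a carboxylic acid attached to the six-membered ring would be tolerated as well. They also leave open what pyridin-3-yl would do in place of the phenyl of compound 1, where that ring sits at a different place on the shared core.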